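Amino Substitution on Two Related Cores in UO-31 Growth Inhibition

The source may report more compounds than this note shows. Statements on the series, on what has been measured and on what is new or still open speak of the compounds shown alone.

Measured compounds:
compound 1, `ClCc1ccc(Cn2cnc3c(Cl)ncnc32)cc1`: 2080 nM
compound 2, `Nc1nc(Cl)c2ncn(Cc3ccc(CCl)cc3)c2n1`: 11800 nM
compound 3, `ClCc1ccccc1Cn1cnc2c(Cl)ncnc21`: 2630 nM

All three were tested in a functional assay on UO-31 cells (Homo sapiens) for cytotoxicity, read by sulforhodamine B assay, with a stated time of 48 h; a higher number here means a weaker inhibitor of growth, a lower number a stronger inhibitor of growth. Compound 1 and compound 2 differ in one place: amino in place of hydrogen on an aromatic carbon
That change produced a 5.7-fold higher number from compound 1 to compound 2 (0.75 log units; beyond the scatter), so the amino compound was the weaker inhibitor of growth.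

Compound 3 is built from the same atoms as compound 1, joined differently; the difference between the two cores is not broken down here. Its value and that of compound 1 lie within the scatter of each other, so no order between them can be read.

Compound 4, `Nc1nc(Cl)c2ncn(Cc3ccccc3CCl)c2n1`, has not yet been measured in this assay. It stands to compound 3 as compound 2 stands to compound 1: amino in place of hydrogen on an aromatic carbon
This is the same change, at the same kind of place. Since compound 3 and compound 1 give similar numbers, the step for compound 4 is expected to resemble a 5.7-fold higher number from compound 1 to compound 2 (0.75 log units; beyond the scatter), and the estimate is a 4.9-fold higher number from compound 3 to compound 4 (0.69 log units; beyond the scatter). Compound 4 is therefore expected to give 13000 nM, with a likely range from 5000 nM to 35000 nM.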

Compound 4, concentration for 50% growth inhibition: 15500 nM
Beside the measured number, compound 4's estimate is 1.2-fold (0.08 log units) below it; the range from low to high includes it.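

In this assay, amino in place of hydrogen on an aromatic carbon again gave the weaker inhibitor of growth, with a 5.9-fold higher number from compound 3 to compound 4 (0.77 log units; beyond the scatter) on the core of compound 3. The step on this core matched the one on the core of compound 1, and the two cannot be told apart: the same change on two cores in this assay, a 5.7-fold higher number (0.75 log units; beyond the scatter) from compound 1 to compound 2 and a 5.9-fold higher number (0.77 log units; beyond the scatter) from compound 3 to compound 4, 1.0-fold (0.02 log units) apart, within the scatter of two such steps. This shows that the change carried over between these two cores, in this one cell line, but it does not explain the step or show that it would hold on any other core.

The compounds shown leave open how other groups would behave at the same place between two ring nitrogen atoms, such as a methylamino group, a dimethylamino group or a hydroxyl group. They also leave open whether a step of this size would persist if the chloro group on the same ring gave way to a methoxy group or a methyl group.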